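Fluorine in place of hydrogen on the phenyl of compound 2

This account rests on a few compounds, and the source may have more. Where it says the series, first, only, none or still open, it means among the compounds named here.

Compound 2 `COc1cc2nc(N3CCCN(C(=O)N4CCOCC4)CC3)cc(N)c2c(-c2ccccc2)c1OC` stands highest of the two numbers in an in vivo ADME assay on the whole organism for metabolic stability, with Canis familiaris (Canis lupus familiaris) as the target, at a dose of 0.5 mg/kg by the intravenous route (a lower number here means that the compound disappears faster, a higher number that the compound lasts longer), where compound 2 gives 3.6 h. Compound 1 `COc1cc2nc(N3CCCN(C(=O)N4CCOCC4)CC3)nc(N)c2c(-c2ccccn2)c1OC` differs from it in more than one place, and in this assay compound 1 gives 1.6 h, a gap beyond the usual scatter. Compound 3 `COc1cc2nc(N3CCCN(C(=O)N4CCOCC4)CC3)cc(N)c2c(-c2ccc(F)cc2)c1OC` has not yet been measured; it differs from compound 2 by fluoro in place of hydrogen on an aromatic carbon. For the measured compounds named here, no step of this kind has been measured, so the expected step of a 1.3-fold higher number from compound 2 to compound 3 (0.10 log units; within the scatter) is small, probably within the scatter, if anything upward. Compound 3 is therefore estimated at 4.5 h, with a range from 2 h to 10 h.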

Compound 3, half-life in the Canis familiaris assay: 6.3 h
Beside the measured number, compound 3's estimate is 1.4-fold (0.15 log units) below it, within the range that was stated.
By their numbers in the Canis familiaris assay, from the lowest: compound 1; then compounds 2 and 3 (each within the scatter of the next).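

In the Canis familiaris assay compound 2 gives 3.6 h and compound 3 gives 6.3 h; putting fluoro in place of hydrogen on this aromatic carbon gives a 1.8-fold higher number from compound 2 to compound 3 (0.24 log units; within the scatter), so this position accepts fluoro without a shift beyond the scatter. In a physicochemical assay for acid dissociation, compound 2 gives 8.5 and compound 3 gives 8.5; the same change gives no change at the digits printed from compound 2 to compound 3 (within the scatter), which means that neither read-out separates the phenyl from the 4-fluorophenyl. Nothing available here accounts for these two results.

The compounds shown leave open whether chloro, a nitrile or an amine on this same carbon would also keep the half-life within the scatter of compound 2. They also leave open how fluoro would read on the other carbons of this ring.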